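A few compounds are considered here, and "the series" means these few. Any claim that something is new, unique, unknown or untested is made for them only; others in the source may bear on it.

Of the compounds shown here, three built on one shared core have been tested in a functional assay on MCF7 cells (Homo sapiens) for cytotoxicity, read by sulforhodamine B assay, with a stated time of 48 h; a lower number here means a stronger inhibitor of growth, a higher number a weaker inhibitor of growth. Compound 1 `Cc1ccc2nc(/N=C3\C(=O)N(CN4CCCCC4)c4ccccc43)sc2c1` gives 37800 nM. Compound 2 `Cc1ccc2nc(/N=C3\C(=O)N(CN(c4ccccc4)c4ccccc4)c4cccc(Br)c43)sc2c1` gives 30200 nM. Compound 3 `Cc1ccc2nc(/N=C3\C(=O)N(CN(c4ccccc4)c4ccccc4)c4cccc(Cl)c43)sc2c1` gives 24300 nM, the lowest of the three numbers, but its gaps to compound 2 and to compound 1 both lie within the usual scatter of such measurements, so no real order among the three can be claimed. Among the measured compounds shown here, the only single-point step in the set, a 1.2-fold lower number from compound 2 to compound 3 (0.09 log units; within the scatter), shows that exchanging one halogen for the other made no difference beyond the scatter.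

Compound 4 `Cc1ccc2nc(/N=C3\C(=O)N(CN(c4ccccc4)c4ccccc4)c4ccccc43)sc2c1` has not yet been measured. Compared with compound 3 it differs by hydrogen in place of chloro on an aromatic carbon, so the halogen at that position is removed altogether. For the measured compounds named here, the step from compound 2 to compound 3 is the only measured change at this position, and it stayed within the scatter; compound 1, which carries no halogen at all, also sits within the scatter of compound 3. On this basis the expected step of a 1.2-fold higher number from compound 3 to compound 4 (0.09 log units; within the scatter) is no change beyond the scatter, in either direction. Compound 4 is therefore estimated at 30000 nM, with a likely range from 12000 nM to 75000 nM.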

Compound 4, concentration for 50% growth inhibition: 39200 nM
Compound 4: the middle estimate sits 1.3-fold (0.12 log units) below what was measured; the measured number falls inside the stated range.
By their numbers in this assay, from the lowest: compounds 3, 2, 1 and 4 (each within the scatter of the next).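

In this assay, taking the halogen off altogether gives a 1.6-fold higher number from compound 3 to compound 4 (0.21 log units; within the scatter), and making the same removal from the bromo compound gives a 1.3-fold higher number from compound 2 to compound 4 (0.11 log units; within the scatter). Until now this aromatic carbon had only been compared with one halogen swapped for the other, whereas these steps compare each halogen with plain hydrogen, and both stay within the usual scatter. Among chloro, bromo and hydrogen at this carbon, then, the choice of group makes no readable difference, and a halogen there is not shown to be needed for the growth inhibition seen in these compounds.

What stays open is whether any group at this carbon can shift the number beyond the scatter, since only two halogens and hydrogen are shown there, and a group of another kind, such as an amine, a carboxylic acid or a longer carbon chain, might behave differently. No supporting measurement is available to explain why these three compounds read alike.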